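The compounds below may be only part of what the source reports. "The series", "measured", "known", "first", "only" and "open" are said of these compounds alone.

Measured compounds:
Compound 1, `O=C(Oc1ccc(Br)cc1C(=O)Nc1ccc(C(F)(F)F)cc1)c1ccc(Br)cc1`: 4200 nM
Compound 2, `O=C(Oc1ccc(Cl)cc1C(=O)Nc1ccc(C(F)(F)F)cc1)c1ccc([N+](=O)[O-])cc1`: 1150 nM

Both were tested in a functional assay on HepG2 cells (Homo sapiens), read by MTT assay, with a stated time of 72 h; on this read-out lower numbers stand for stronger inhibition and higher numbers for weaker inhibition. On these two numbers compound 2 stands lowest, and compound 1 sits well above it, a gap that lies beyond the usual scatter of repeated measurements.

Compound 3, `O=C(Oc1ccc(Cl)cc1C(=O)Nc1ccc(C(F)(F)F)cc1)c1ccc(Br)cc1`, has not yet been measured. It differs from compound 2 in one place: bromo in place of nitro on an aromatic carbon. Put another way, the 4-nitrophenyl part of compound 2 becomes a 4-bromophenyl part in compound 3.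

Within the data shown here, no measured pair shows this exact swap, so the expectation rests on the two numbers available. With compound 1 giving 4200 nM as the other point of reference, a moderate loss from the level of compound 2 is expected. The expected step of a 2.4-fold higher number from compound 2 to compound 3 (0.39 log units; beyond the scatter) is a rise somewhat beyond the scatter. Compound 3 is therefore estimated at 2800 nM, with a likely range from 1100 nM to 7500 nM.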

Compound 3, half-maximal inhibitory concentration: 14500 nM
Compound 3: the middle estimate sits 5.2-fold (0.71 log units) below what was measured; measured number above the stated range.
By their numbers in this assay, from the lowest: compound 2; then compound 1; then compound 3.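

In this assay the group on this aromatic carbon, para to a large group, matters a great deal: bromo in place of nitro gives a 13-fold higher number from compound 2 to compound 3 (1.10 log units; beyond the scatter) and so a large loss of inhibition. The second halogen site also counts, though less, as chloro in place of bromo gives a 3.5-fold higher number from compound 1 to compound 3 (0.54 log units; beyond the scatter) and so a modest loss that still lies beyond the scatter. No measurement at hand explains either step.

The compounds shown leave open whether the nitro group itself is needed, or whether a nitrile, an amine or a carboxylic acid in the same place would hold the level of compound 2. They also leave open whether the change between bromo and chloro would have the same effect with the 4-nitrophenyl part in place.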